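Replacing the thiophene carbonyl with a 2-methylbenzoyl group

The source may hold more compounds than are shown below. What is called first, only, known or untested is meant among the compounds shown, and "the series" means these compounds.

Among the compounds with values here, compound 3, with structure `COc1cc(-c2nnc3n2NC(c2ccco2)C(C(=O)c2cccs2)S3)cc(OC)c1OC`, gives 64100 nM in a functional assay on HepG2 cells (Homo sapiens) for cytotoxicity, read by MTT assay, with a stated time of 48 h (on this read-out higher numbers stand for weaker inhibition and lower numbers for stronger inhibition), and that is the only number in this set. Compound 1, with structure `COc1ccc(C(=O)C2Sc3nnc(-c4cc(OC)c(OC)c(OC)c4)n3NC2c2ccco2)cc1`, gives a limit, > 100000 nM, in this assay. Compound 2, with structure `COc1cc(-c2nnc3n2NC(c2ccco2)C(C(=O)C2CC2)S3)cc(OC)c1OC`, likewise gives a limit, > 100000 nM, in this assay. Within the data shown here, the two steps toward the only number read an at least 1.5-fold lower number from compound 1 to compound 3 (0.19 log units; that floor lies within the scatter) and an at least 1.5-fold lower number from compound 2 to compound 3 (0.19 log units; that floor lies within the scatter), so both are floors and neither is certainly beyond the scatter.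

Compound 4, with structure `COc1cc(-c2nnc3n2NC(c2ccco2)C(C(=O)c2ccccc2C)S3)cc(OC)c1OC`, has not yet been measured. It differs from compound 3 by 2-methylphenyl in place of thiophen-2-yl on a carbonyl carbon. The nearest measured guide is an at least 1.5-fold lower number from compound 1 to compound 3 (0.19 log units; that floor lies within the scatter), where a six-membered aromatic ring of carbon only on the carbonyl carbon in compound 1 sat at the limit (the limit of > 100000 nM in this assay, at which 2 of the 3 values shown sit). A return of that kind is therefore expected for compound 4: a small rise in the number, or a limit, with a step of a 1.4-fold higher number from compound 3 to compound 4 (0.15 log units; within the scatter) that is not reliably readable. Compound 4 is estimated at 90000 nM, within a range from 40000 nM to 200000 nM.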

Compound 4, half-maximal inhibitory concentration: 63000 nM
Beside the measured number, compound 4's estimate is 1.4-fold (0.15 log units) above it; low and high end bracket the measured number.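

In this assay, a six-membered aromatic ring of carbon only on the carbonyl carbon does not by itself bring a limit: 2-methylphenyl gives a readable number, and the change from thiophen-2-yl gives a 1.0-fold lower number from compound 3 to compound 4 (0.01 log units; within the scatter), so the two groups cannot be told apart at this position. Set against the two groups that gave no number, the change gives an at least 1.5-fold lower number from compound 1 to compound 4 (0.20 log units; that floor lies within the scatter) and an at least 1.5-fold lower number from compound 2 to compound 4 (0.20 log units; that floor lies within the scatter), and these floors do not show that 2-methylphenyl truly differs from 4-methoxyphenyl or cyclopropyl. The readings of compound 1 and compound 2 remain limits rather than numbers: the limit of > 100000 nM in this assay, at which 2 of the 4 values shown sit.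

Going by these compounds, what a plain phenyl, a 4-methylphenyl or a pyridin-2-yl would read on this carbonyl carbon remains open, so the part played by the methyl group of 2-methylphenyl cannot be separated from that of the ring. Also open, on these data alone, is whether an amine or a carboxylic acid carried on this ring would move the number clearly beyond the scatter, since the shared core is the same in all four compounds and only this one position varies.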